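A second fluoro group on the aryl amide: cytotoxicity outlook

A few compounds are considered here, and "the series" means these few. Any claim that something is new, unique, unknown or untested is made for them only; others in the source may bear on it.

Compound 1 `Cc1ccc(NC(=O)C(=O)NC(c2nc(C)c(CCO)s2)C2CCCCN2)cc1F`: in an ADME assay on TZM-b1 cells (Homo sapiens) for cytotoxicity, read by XTT assay, with a stated time of 3 days (a higher number here means that more compound is tolerated, a lower number that less compound is tolerated), compound 1 gives > 85000 nM, which is a limit of the assay, not a number.
Compound 2 `Cc1nc(C(NC(=O)C(=O)Nc2ccc(F)cc2)C2CCCCN2)sc1CCO`: in this assay compound 2 gives > 88000 nM, again a limit rather than a number.

Compound 2 thus stands at the edge of what this assay reports, with only a limit to its name. Going by the values given here, the one other value shown, that of compound 1, is likewise a limit. Among the compounds with values here, the only measured step, a step that the two limits leave unreadable from compound 1 to compound 2, cannot be read, as the limit of > 85000 nM in this assay, at which 1 of the 2 values shown sits, and the limit of > 88000 nM in this assay, at which 1 of the 2 values shown sits, show. Compound 3 `Cc1nc(C(NC(=O)C(=O)Nc2ccc(F)cc2F)C2CCCCN2)sc1CCO` differs from compound 2 by fluoro in place of hydrogen on an aromatic carbon of a six-membered aromatic ring of carbon only, so that 4-fluorophenyl becomes 2,4-difluorophenyl. Within the data shown here, no measured step bears on this change beyond the unreadable one already named, so no step beyond the scatter is expected in this assay, and the expected step is a step that the limit leaves unreadable from compound 2 to compound 3. Compound 3 is therefore estimated at 90000 nM, between 40000 nM and 200000 nM, most probably reported once more as a limit.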

Compound 3, half-maximal cytotoxic concentration: > 84000 nM
Compound 3 ended at the assay's limit (the forecaster's own chance of this, stated with the estimate: 80%); the middle value lies beyond the limit too.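

In this assay compound 3 gives > 84000 nM, again a limit and not a number. Going by these compounds alone, with only limits for compound 1, compound 2 and compound 3, no step among them can be read. The compounds shown leave open at what concentration any of the three becomes cytotoxic, and whether fluoro in place of hydrogen changes that concentration.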